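Compound 4: two chlorines on the phenyl of compound 1

The compounds below may be only part of what the source reports. "The series", "measured", "known", "first", "only" and "open" are said of these compounds alone.

Compound 1 `O=C(/C=C\c1ccccc1)N1N=C(c2ccncc2)OC1c1c[nH]c2ccccc12` was run in an ADME assay on HeLa cells (Homo sapiens) for cytotoxicity, read by MTT assay, with a stated time of 72 h; on this read-out higher numbers stand for weaker inhibition of growth and lower numbers for stronger inhibition of growth. In this assay compound 1 gives > 30 ug/mL, and that value is a limit of the assay rather than a measured number. Two relatives that differ from compound 1 in one place have also been run. Compound 2 `COc1ccc(/C=C\C(=O)N2N=C(c3ccncc3)OC2c2c[nH]c3ccccc23)cc1` gives > 30 ug/mL, again a limit. Compound 3 `O=C(/C=C\c1cccc(Cl)c1)N1N=C(c2ccncc2)OC1c1c[nH]c2ccccc12` gives > 30 ug/mL, once more a limit. Because all three values sit at the limit of > 30 ug/mL in this assay, at which 3 of the 3 values shown sit, none of the steps among them can be read: a step that the two limits leave unreadable from compound 1 to compound 2, a step that the two limits leave unreadable from compound 1 to compound 3 and a step that the two limits leave unreadable from compound 2 to compound 3 all remain without a size.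

Compound 4 `O=C(/C=C\c1cccc(Cl)c1Cl)N1N=C(c2ccncc2)OC1c1c[nH]c2ccccc12` has not yet been measured in this assay. It differs from compound 1 by 2,3-dichlorophenyl in place of phenyl on a double-bonded chain carbon bound to a double-bonded chain carbon. The measured steps that bear on this change are the addition of a single chloro or methoxy to the same phenyl, and both of those steps are unreadable; neither shows any departure from the limit. No step beyond the scatter is therefore expected in either direction, and the most likely outcome is that compound 4 also returns only a limit. On that basis compound 4 is estimated at 45 ug/mL, within 15 ug/mL to 150 ug/mL, and the expected step is a step that the limit leaves unreadable from compound 1 to compound 4.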

Compound 4, concentration for 50% growth inhibition: > 30 ug/mL
Compound 4: a limit, no number (the forecaster's own chance of this, stated with the estimate: 75%); the middle value does not contradict the limit.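

Compound 4 returns only a limit, and its steps to compound 1, compound 2 and compound 3 cannot be read: the limit of > 30 ug/mL in this assay, at which 4 of the 4 values shown sit. The compounds shown leave open whether any of these changes on the phenyl alters growth inhibition in this assay, as none of the four yields a measured number there.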